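The source may hold more compounds than are shown below. What is called first, only, known or untested is meant among the compounds shown, and "the series" means these compounds.

Working notes on the series. Going by the values given here, compound 1 `CC(=O)OC(C)Cn1cnc2c(Cl)nc(I)nc21` is the one member with a number in an ADME assay on L1210/0 cells (Mus musculus) for cytotoxicity, with a stated time of 48 h; on this read-out higher numbers stand for weaker inhibition and lower numbers for stronger inhibition: compound 1 gives 13000 nM. Compound 2 `O=c1[nH]c(=O)n([C@H]2C[C@H](O)[C@@H](CO)O2)cc1C#CCO` returns only a limit of the assay in this assay, > 200000 nM. Compound 3 `CC#Cc1cn([C@H]2C[C@H](O)[C@@H](CO)O2)c(=O)[nH]c1=O` likewise returns only a limit in this assay, > 200000 nM. Among the compounds with values here, the single one-point step so far, a step that the two limits leave unreadable from compound 2 to compound 3, runs between two limits and its size cannot be read. Compound 3 thus stands at the limit of > 200000 nM in this assay, at which 2 of the 3 values shown sit, with no number of its own.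

Compound 4 `O=c1[nH]c(=O)n([C@H]2C[C@H](O)[C@@H](CO)O2)cc1O` differs from compound 3 in one place: hydroxy in place of prop-1-yn-1-yl on an aromatic carbon. Within the data shown here, no measured step bears on this change, and the only step present carries no size to transfer. For compound 4 the expectation is only that it also reaches the limit, with no direction beyond the scatter assignable. The step of a number no higher from compound 3 to compound 4 (the limit leaves the size open) is estimated as no change beyond the scatter. Compound 4 is estimated at 200000 nM, range 50000 nM to 500000 nM, most likely reported as a limit.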

Compound 4, half-maximal inhibitory concentration: > 200000 nM
Compound 4 ended at the assay's limit; the forecaster's own chance of this, stated with the estimate: 70%; the middle value sits exactly at the limit.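

The steps among compound 2, compound 3 and compound 4 cannot be read, as all three values in this assay are limits: the limit of > 200000 nM in this assay, at which 3 of the 4 values shown sit. The compounds shown leave open how far each of the three lies past that limit, and whether swapping the group on the aromatic carbon changes the read-out at all.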